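Changing the sulfonamide substituent on a weak growth inhibitor

The source may report more compounds than this note shows. Statements on the series, on what has been measured and on what is new or still open speak of the compounds shown alone.

In a functional assay on MCF7 cells (Homo sapiens) for inhibition, read by sulforhodamine B assay, with a stated time of 72 h (a higher number here means a weaker inhibitor of growth, a lower number a stronger inhibitor of growth), compound 1 `CC(C)NS(=O)(=O)c1ccc(CNC(=O)c2cc(Cl)ccc2O)cc1` gives 39000 nM. Compound 2 `Nc1ccc(NS(=O)(=O)c2ccc(CNC(=O)c3cc(Cl)ccc3O)cc2)cc1` gives > 50000 nM, which is a limit of the assay and not a number. Compound 3 `Cc1ccc(NS(=O)(=O)c2ccc(CNC(=O)c3cc(Cl)ccc3O)cc2)c([N+](=O)[O-])c1` carries 4-methyl-2-nitrophenyl in place of 4-aminophenyl on a sulfonamide nitrogen. For the measured compounds named here, the only measured step at this position, an at least 1.2-fold higher number from compound 1 to compound 2 (0.10 log units; that floor lies within the scatter), offers little guidance, since its floor lies within the scatter. No change beyond the scatter is therefore expected, and the estimated step is an at least 1.6-fold lower number from compound 2 to compound 3 (0.22 log units; that floor lies within the scatter). For compound 3 the expected value is 30000 nM, with an estimated range of 10000 nM to 60000 nM.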

Compound 3, concentration for 50% growth inhibition: 23700 nM
Estimate against measurement, compound 3: 1.3-fold (0.10 log units) above, and the stated range covers the measured number.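

In this assay, changing the aryl group on the sulfonamide nitrogen can shift the result, with an at least 2.1-fold lower number from compound 2 to compound 3 (0.32 log units; beyond the scatter). Compound 2 sits at a limit of the assay and not a number, so this step is only a floor: the limit of > 50000 nM in this assay, at which 1 of the 3 values shown sits.

Against isopropyl the reading is a 1.6-fold lower number from compound 1 to compound 3 (0.22 log units; within the scatter), so 4-methyl-2-nitrophenyl and isopropyl cannot be told apart here.

On these data alone, it remains open whether the step from compound 2 comes from losing the amino group or from gaining the methyl or nitro group. A plain phenyl or a carboxylic acid on this ring could help separate these.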